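Compound 1 to compound 4: cytotoxicity working notes

This account rests on a few compounds, and the source may have more. Where it says the series, first, only, none or still open, it means among the compounds named here.

Measured so far in an ADME assay on HCT-116 cells (Homo sapiens) for cytotoxicity, read by CellTiter-Glo, with a stated time of 72 h (on this read-out higher numbers stand for weaker inhibition and lower numbers for stronger inhibition), for this series
compound 1 `Cc1cc(C)c(S(=O)(=O)N2CCC(N3CCC(CCO)CC3)CC2)c(C)c1` gives > 5000 nM
compound 2 `Cc1cc(C)c(S(=O)(=O)N2CCC(c3ccccc3)CC2)c(C)c1` gives > 5000 nM
compound 3 `CCCC(=O)NC1CCN(S(=O)(=O)c2c(C)cc(C)cc2C)CC1` gives > 5000 nM

Compound 1 stands at > 5000 nM as a limit of the assay, not a number. The whole set offers only the limit of > 5000 nM in this assay, at which 3 of the 3 values shown sit, and no ranking follows from that.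

Compound 4 `Cc1cc(C)c(S(=O)(=O)N2CCC(N3CCC(Cc4ccccc4F)CC3)CC2)c(C)c1` differs from compound 1 on the chain (2-fluorophenyl in place of hydroxymethyl on a saturated chain carbon bound to a saturated ring carbon). Cut one bond further out, the same difference reads 2-hydroxyethyl to 2-fluorobenzyl.

The measured steps bear on this only loosely. There is a step that the two limits leave unreadable from compound 1 to compound 2 and also a step that the two limits leave unreadable from compound 1 to compound 3 and finally a step that the two limits leave unreadable from compound 2 to compound 3 in the set, all on a saturated ring carbon. None gives a size to carry over, and none gives a direction. The expected step is a number no higher from compound 1 to compound 4 (the limit leaves the size open) with no direction favoured. Another limit is the likeliest report, an expectation due to the limit of > 5000 nM in this assay, at which 3 of the 3 values shown sit, and nothing more. Compound 4 is estimated at 5000 nM with an expected range from 1500 nM to 12000 nM in this assay for now.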

Compound 4, half-maximal inhibitory concentration: > 5000 nM
Compound 4 was reported as a limit; the forecaster's own chance of this, stated with the estimate: 70%; the middle value sits exactly at the limit.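

In this assay compound 4 gives > 5000 nM, a limit of the assay and not a number. With compound 1 also reported as a limit, no new step can be read from compound 1 to compound 4. The compounds shown leave open how any of them would rank on a measured number: the limit of > 5000 nM in this assay, at which 4 of the 4 values shown sit.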